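Working notes: compound 3 to compound 4, aryl halogen change

The source may hold more compounds than are shown below. What is called first, only, known or untested is meant among the compounds shown, and "the series" means these compounds.

Three compounds of the series have numbers in a functional assay on SK-BR-3 cells (Homo sapiens) for antiproliferative activity, read by MTT assay, with a stated time of 72 h; a higher number here means a weaker inhibitor, a lower number a stronger inhibitor. Compound 1 `CCN(CC)CCNc1cc(C)c2cc(NC(=O)c3ccc(Cl)c(Cl)c3)ccc2n1` gives 3710 nM, compound 2 `Cc1cc(NCCN2CCN(C)CC2)nc2ccc(NC(=O)c3ccc(Cl)c(Cl)c3)cc12` gives 2690 nM, and compound 3 `CCN1CCN(c2cc(C)c3cc(NC(=O)c4ccc(Cl)cc4)ccc3n2)CC1` gives 3020 nM. Among the measured compounds shown here, the one single-point step among them, a 1.4-fold lower number from compound 1 to compound 2 (0.14 log units; within the scatter), concerns the amine side of the molecule and stays within the scatter. Compound 3 stands second highest of the three numbers; compound 2 is nearest, compound 1 furthest, and both gaps lie within the scatter, so the three compounds are not separable on these data.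

Compound 4 `CCN1CCN(c2cc(C)c3cc(NC(=O)c4ccccc4Br)ccc3n2)CC1` is not yet measured. It differs from compound 3 in one place: 2-bromophenyl in place of 4-chlorophenyl on a carbonyl carbon. For the measured compounds named here, no measured step touches this part of the molecule; compound 1 and compound 3 differ there, but also on the amine side, and their two values sit within the scatter of each other. Going by the values given here, there is therefore no precedent pointing in either direction, and the expectation is a step of no more than the scatter, a 1.1-fold higher number from compound 3 to compound 4 (0.03 log units; within the scatter), with the range kept wide for the lack of a comparable step. Compound 4 is estimated at 3200 nM, between 1200 nM and 8500 nM.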

Compound 4, half-maximal inhibitory concentration: 39200 nM
Compound 4: the middle estimate sits 12-fold (1.09 log units) below what was measured; the measured number lies above the stated range.
By their numbers in this assay, from the lowest: compounds 2, 3 and 1 (each within the scatter of the next); then compound 4.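

In this assay, the aryl group on the carbonyl carbon proves to be a sensitive position: 2-bromophenyl in place of 4-chlorophenyl gives a 13-fold higher number from compound 3 to compound 4 (1.11 log units; beyond the scatter). Among the compounds shown here, this is the first step beyond the scatter, and it moves the number towards a weaker inhibitor, whereas the earlier amine-side step stayed within the scatter. The two groups have the same heavy-atom count and the same counts of hydrogen-bond donors and acceptors, and neither carries a net charge, so these counts do not separate them, and no available measurement bears on the reason for the step.

The change replaces chlorine with bromine and alters the halogen's place on the ring in one move, so the compounds shown cannot assign the step to either part; the 2-chlorophenyl and 4-bromophenyl amides, with the amine of compound 3 kept, would separate the two. Also open, from the compounds shown here alone, is whether an unsubstituted phenyl group would sit with compound 3 or compound 4, and whether the same 2-bromophenyl change behaves alike with the amine side chains of compound 1 and compound 2.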